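This account rests on a few compounds, and the source may have more. Where it says the series, first, only, none or still open, it means among the compounds named here.

Compound 1 `Nc1ncnc2c1c(-c1cnc3[nH]ccc3c1)nn2CC(=O)NO` and compound 3 `Nc1ncnc2c1c(-c1cnc3[nH]ccc3c1)nn2CCC(=O)NO` share one core; compound 2 `Nc1nc2cc(-c3nn(CCCCC(=O)NO)c4ncnc(N)c34)ccc2o1` and compound 4 `Nc1nc2cc(-c3nn(CCCCCC(=O)NO)c4ncnc(N)c34)ccc2o1` share another, and the difference between the two cores is not broken down here. In a functional assay on MDA-MB-231 cells (Homo sapiens) for inhibition, read by MTT assay, with a stated time of 72 h (on this read-out higher numbers stand for weaker inhibition and lower numbers for stronger inhibition), compound 1 gives only a limit, > 150000 nM. Compound 3 likewise gives only a limit in this assay, > 150000 nM. The step that the two limits leave unreadable from compound 1 to compound 3, made by (hydroxycarbamoyl)methyl in place of hydroxycarbamoyl on a saturated chain carbon bound to an aromatic nitrogen, is unreadable because of the limit of > 150000 nM in this assay, at which 2 of the 3 values shown sit. Among the measured compounds shown here, compound 2 gives 21200 nM in this assay, the one number in the set. The change to compound 4 is (hydroxycarbamoyl)methyl in place of hydroxycarbamoyl on a saturated chain carbon, four bonds along the chain from an aromatic nitrogen; it is the same kind of change as that from compound 1 to compound 3, but the place differs, being four bonds along the chain from an aromatic nitrogen rather than bound to it. For the measured compounds named here, the step of a 1.4-fold lower number from compound 2 to compound 4 (0.15 log units; within the scatter) is expected to be modest, as no measured pair reads this chain extension. Compound 4 is estimated at 15000 nM, with 5000 nM to 50000 nM as its likely span.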

Compound 4, half-maximal inhibitory concentration: 19000 nM
Estimate against measurement, compound 4: 1.3-fold (0.10 log units) below; low and high end bracket the measured number.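

In this assay, (hydroxycarbamoyl)methyl in place of hydroxycarbamoyl, four bonds along the chain from an aromatic nitrogen, gives a 1.1-fold lower number from compound 2 to compound 4 (0.05 log units; within the scatter), so on this core the change cannot be told from scatter. This single pair does not show that the result carries to the core of compound 1, where the same kind of change sits on a saturated chain carbon bound to an aromatic nitrogen. The step on that core cannot be read, so no comparison between the cores is possible, because both of its values are limits: the limit of > 150000 nM in this assay, at which 2 of the 4 values shown sit.

Open, from the compounds shown here alone, is how the chain of compound 4 would read on the core of compound 1. Also open, going by these compounds, is how a longer chain, or a carboxylic acid in place of hydroxycarbamoyl, would read on either core.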